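Replacing the butyl chain's end with a dimethylamino group

The source may report more compounds than this note shows. Statements on the series, on what has been measured and on what is new or still open speak of the compounds shown alone.

In a functional assay on MDA-MB-231 cells (Homo sapiens) for cytotoxicity, read by sulforhodamine B assay, with a stated time of 48 h, in the presence of a further agent that is not named here (on this read-out higher numbers stand for weaker inhibition of growth and lower numbers for stronger inhibition of growth), compound 1 `CCCCNc1ccnc2cc(Cl)ccc12` gives 11300 nM and compound 2 `CCCCNc1ccnc2cc(F)ccc12` gives 12300 nM; the step of a 1.1-fold higher number from compound 1 to compound 2 (0.04 log units; within the scatter) lies within the scatter, so the two values stand level. Compound 3 `CN(C)CCNc1ccnc2cc(F)ccc12` differs from compound 2 by dimethylamino in place of ethyl on a saturated chain carbon, two bonds along the chain from a nitrogen on an aromatic ring, so that butyl becomes 2-(dimethylamino)ethyl. Among the measured compounds shown here, no measured step touches this chain, and the only known step concerns a halogen, so no direction is supported by the data. The expectation for this assay is therefore a change no larger than the scatter, a 1.2-fold lower number from compound 2 to compound 3 (0.09 log units; within the scatter), and compound 3 is estimated at 10000 nM, between 4000 nM and 30000 nM.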

Compound 3, concentration for 50% growth inhibition: 9450 nM
For compound 3 the middle estimate is 1.1-fold (0.02 log units) above the measured one, and the stated range covers the measured number.
By their numbers in this assay, from the lowest: compounds 3, 1 and 2 (each within the scatter of the next).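

In this assay, the change from butyl to 2-(dimethylamino)ethyl gives a 1.3-fold lower number from compound 2 to compound 3 (0.11 log units; within the scatter). The earlier step concerned only the halogen, whereas this one shows that placing dimethylamino in place of ethyl on the chain leaves the number level with that of the butyl compound. Nothing measured here bears on why the two stand level.

From the compounds shown here alone, whether a morpholine or a carboxylic acid on this chain, or a longer chain carrying dimethylamino, would shift the number beyond the scatter remains open. So does whether chloro in place of fluoro would stay level with the 2-(dimethylamino)ethyl chain.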